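Urea-linked quinazolinone series: methoxy for ethyl on the aryl ring

This account rests on a few compounds, and the source may have more. Where it says the series, first, only, none or still open, it means among the compounds named here.

Compound 1: `CCc1ccc(NC(=O)Nn2c(-c3ccccc3)nc3ccccc3c2=O)cc1` — 61%
Compound 2: `CCc1nc2ccccc2c(=O)n1NC(=O)Nc1ccccc1` — 54%
Compound 3: `CCc1ccc(NC(=O)Nn2c(CC)nc3ccccc3c2=O)cc1` — 58%

All three numbers come from a functional assay on the whole organism (strain albino) with Mus musculus as the target, at a dose of 100 mg/kg by the intraperitoneal route; a higher number here means more inhibition at the dose given (going by the name of the read-out), a lower number less inhibition. Compound 3 sits between compound 1 and compound 2 on this assay, and both of its steps are within the scatter: a number 3 percentage points lower from compound 1 to compound 3 (within the scatter) with ethyl in place of phenyl on an aromatic carbon, and a number 4 percentage points higher from compound 2 to compound 3 (within the scatter) with ethyl in place of hydrogen on an aromatic carbon. The three compounds are therefore not distinguishable on this assay.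

Compound 4 is `CCc1nc2ccccc2c(=O)n1NC(=O)Nc1ccc(OC)cc1`. It differs from compound 3 by methoxy in place of ethyl on an aromatic carbon. Within the data shown here, the step that bears most directly on it is the one from compound 2 to compound 3, which changed the same aromatic carbon and stayed within the scatter; the step from compound 1 to compound 3 touched a different place and was also within the scatter. No step beyond the scatter is expected for compound 4 in this assay, so the estimated change is a number 2 percentage points lower from compound 3 to compound 4 (within the scatter). Compound 4 is estimated at 56%, with a range from 42% to 70%.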

Compound 4, a percentage reported as inhibition, in the whole organism at one dose (the size of the read-out at that dose, not a potency): 48%
Compound 4: the middle estimate sits 8 percentage points above what was measured; measured number inside the range.
By their numbers in this assay, from the lowest: compounds 4, 2, 3 and 1 (each within the scatter of the next, the first and the last beyond it).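

Methoxy at this aromatic carbon can now be set against both ethyl and hydrogen in this assay, on the core that carries ethyl: the swap of 4-ethylphenyl to 4-methoxyphenyl gives a number 10 percentage points lower from compound 3 to compound 4 (within the scatter) and the addition of methoxy gives a number 6 percentage points lower from compound 2 to compound 4 (within the scatter) on that same core. Hydrogen, ethyl and methoxy at this carbon are therefore not separated by this read-out, so bringing in an oxygen and a hydrogen-bond acceptor here produces no step beyond the scatter. Nothing measured bears on the reason for these numbers.

As far as these compounds go, whether any group at this carbon can move the number beyond the scatter stays open, and an amine, a carboxylic acid or a longer chain would test that. Also open, from the compounds shown here alone, is whether methoxy here reads the same when the core carries phenyl in place of ethyl.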